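Stripping the (methylsulfonyl)methyl Group from Compound 2

The source may report more compounds than this note shows. Statements on the series, on what has been measured and on what is new or still open speak of the compounds shown alone.

Of the compounds shown here, two have been measured in an assay on CHO cells for displacement of a labelled ligand from prostaglandin D2 receptor 2 (Homo sapiens), read by scintillation counting; on this read-out higher numbers stand for weaker inhibition and lower numbers for stronger inhibition. Compound 1 `Cc1ncccc1C#Cc1cc(Cl)ccc1OCC(=O)O` gives 143 nM, and compound 2 `CS(=O)(=O)Cc1cccc(C#Cc2cc(Cl)ccc2OCC(=O)O)c1` gives 48 nM. Compound 2 thus stands at the lowest of the two numbers, and the higher number of compound 1 lies beyond the usual scatter of repeated measurements.

Compound 3 `O=C(O)COc1ccc(Cl)cc1C#Cc1ccccc1` is not yet measured. It differs from compound 2 in a single place: hydrogen in place of (methylsulfonyl)methyl on an aromatic carbon. Going by the values given here, no pair of measured compounds differs by this change, so the data give no direct guide to its size.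

Because compound 2 gives 48 nM with the (methylsulfonyl)methyl group in place, and compound 1 gives 143 nM with a different group there, the removal is expected to raise the number, with a step estimated at a 4.2-fold higher number from compound 2 to compound 3 (0.62 log units; beyond the scatter). For compound 3 in this assay the estimate is 200 nM, within a range from 60 nM to 700 nM.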

Compound 3, inhibition constant: 108 nM
The estimate for compound 3 lay 1.9-fold (0.27 log units) above the measured number; the measured number falls inside the stated range.
By their numbers in this assay, from the lowest: compound 2; then compounds 3 and 1 (each within the scatter of the next).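

In this assay, taking away the (methylsulfonyl)methyl group gives a 2.3-fold higher number from compound 2 to compound 3 (0.35 log units; beyond the scatter), so the group has a real but modest effect at this position, and compound 3 with only hydrogen there still gives 108 nM. Putting phenyl in place of 2-methylpyridin-3-yl on the triple-bonded carbon gives a 1.3-fold lower number from compound 1 to compound 3 (0.12 log units; within the scatter), so this assay does not separate these two groups. Nothing at hand gives a reason for either step.

From the compounds shown here alone, it remains open whether a simple methyl, a methylsulfonyl group attached directly to the ring, a sulfonamide or an amine at this position would match compound 2. Going by these compounds, it also remains open whether the same group would give a step of similar size on the 2-methylpyridin-3-yl ring of compound 1.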